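Swapping methyl for fluoro on a weakly active compound

The source may hold more compounds than are shown below. What is called first, only, known or untested is meant among the compounds shown, and "the series" means these compounds.

The measurements in a functional assay on KB cells (Homo sapiens) for antiproliferative activity, read by sulforhodamine B assay, with a stated time of 3 days (on this read-out lower numbers stand for an effect already at smaller amounts and higher numbers for an effect only at larger amounts of compound), cover three compounds, two of them only as limits:
Compound 1 (`CCC1=C(O)c2c(oc(-c3ccc(CBr)cc3)cc2=O)C(CC)(CC)C1=O`), a limit: > 46.5 uM
Compound 2 (`CCC1=C(O)c2c(oc(-c3ccc(COC)cc3)cc2=O)C(CC)(CC)C1=O`), a limit: > 52.4 uM
Compound 3 (`CCC1=C(O)c2c(oc(-c3cccc(C)c3)cc2=O)C(CC)(CC)C1=O`), a number: 49.7 uM

Among the measured compounds shown here, compound 3 holds the only true number of the three, 49.7 uM, and so it is the one firm starting point here. Compound 4 (`CCC1=C(O)c2c(oc(-c3cccc(F)c3)cc2=O)C(CC)(CC)C1=O`) keeps everything in compound 3 except one small group: fluoro in place of methyl on an aromatic carbon, meta to a large group (fluoro in place of methyl on an aromatic carbon).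

For the measured compounds named here, no measured step makes this exchange, so the evidence is indirect. Two steps give no size at all: a step that the two limits leave unreadable from compound 1 to compound 2, and a step that the limit leaves unreadable from compound 1 to compound 3. The third, which also changes the group on the aromatic carbon, is an at least 1.0-fold lower number from compound 2 to compound 3 (0.02 log units; that floor lies within the scatter). That step offers only a floor, and it lies within the scatter. Much larger changes to this group have therefore shown no readable shift, and nothing measured points to a real move in either direction for a swap of one small group.

The expected result is a 1.1-fold lower number from compound 3 to compound 4 (0.04 log units; within the scatter), with no change beyond the scatter. For compound 4 the estimated value is 45 uM, with an expected range from 20 uM to 70 uM.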

Compound 4, concentration for half-maximal effect: > 56.2 uM
Compound 4: only a limit was reported (the forecaster's own chance of this, stated with the estimate: 45%); middle value at least 1.2-fold (0.09 log units) away from the limit.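

In this assay, the exchange of methyl for fluoro on this aromatic carbon now has a direct reading, an at least 1.1-fold higher number from compound 3 to compound 4 (0.05 log units; that floor lies within the scatter); this shows no change that can be told apart from the scatter, yet it does not fix the size of the step, which could be larger than that floor. Compound 4 is reported only as a limit: the limit of > 56.2 uM in this assay, at which 1 of the 4 values shown sits. Among the compounds shown here, the steps to compound 4 from compound 1 and compound 2 cannot be read, which leaves compound 3 as the only compound here with a true number and gives the series no second firm point for comparison.

Still open, on these data alone, is how far compound 4 really lies from compound 3, since only a true number for compound 4 could settle whether fluoro in place of methyl matters here at all. Also open, as far as these compounds go, is what a clearly different group on this same aromatic carbon would do, such as an amine, a carboxylic acid or a longer chain, and whether any of these would move the number beyond the scatter.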